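Three aryl amines compared, and a trifluoromethylphenyl analogue awaited

A few compounds are considered here, and "the series" means these few. Any claim that something is new, unique, unknown or untested is made for them only; others in the source may bear on it.

Compound 1 `FC(F)(F)c1ccc(CSc2nc(N3CCCCC3)c3ccccc3n2)cc1` gives 18600 nM in a functional assay on MGC-803 cells (Homo sapiens) for cytotoxicity, read by MTT assay, with a stated time of 72 h; a lower number here means a stronger inhibitor, a higher number a weaker inhibitor.
Compound 2 `FC(F)(F)c1ccc(CSc2nc(Nc3ccccc3Cl)c3ccccc3n2)cc1` reaches only the limit > 50000 nM in this assay, and that is a limit, not a number.
Compound 3 `FC(F)(F)c1ccc(CSc2nc(Nc3cccc(Br)c3)c3ccccc3n2)cc1` gives 23700 nM in this assay.

Compound 3 carries the highest of the two numbers actually reported; its nearest neighbour is compound 1, separated by a 1.3-fold higher number from compound 1 to compound 3 (0.11 log units; within the scatter), so the two cannot be ordered. Compound 2 sits at the limit of > 50000 nM in this assay, at which 1 of the 3 values shown sits, and from it the step of an at least 2.1-fold lower number from compound 2 to compound 3 (0.32 log units; beyond the scatter) shows that the aryl group on the amine nitrogen matters.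

Compound 4 `FC(F)(F)c1ccc(CSc2nc(Nc3ccc(C(F)(F)F)cc3)c3ccccc3n2)cc1` differs from compound 3 in one place: 4-(trifluoromethyl)phenyl in place of 3-bromophenyl on a nitrogen on an aromatic ring. Among the compounds with values here, no measured step exchanges one substituted phenyl for another at this nitrogen except the one from compound 2 to compound 3, which moved by an at least 2.1-fold lower number from compound 2 to compound 3 (0.32 log units; beyond the scatter) and shows that such a swap can reach beyond the scatter in either direction. Within the data shown here, with no closer precedent, the expected step of a 1.1-fold higher number from compound 3 to compound 4 (0.02 log units; within the scatter) is set near zero with wide uncertainty. Compound 4 is therefore estimated at 25000 nM in this assay, within 8000 nM to 80000 nM.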

Compound 4, half-maximal inhibitory concentration: 6170 nM
Compound 4: the middle estimate sits 4.1-fold (0.61 log units) above what was measured, outside the stated range (below it).
By their numbers in this assay, from the lowest: compound 4; then compounds 1 and 3 (each within the scatter of the next). At a limit, above all of these: compound 2.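

Within the data shown here, exchanging 3-bromophenyl for 4-(trifluoromethyl)phenyl on this nitrogen gives, in this assay, a 3.8-fold lower number from compound 3 to compound 4 (0.58 log units; beyond the scatter), the first change at this position that lowers the number with real values on both sides. It also separates an aryl amine from the piperidin-1-yl compound, which compound 3 did not do, with a 3.0-fold lower number from compound 1 to compound 4 (0.48 log units; beyond the scatter), so an aryl amine on this aromatic carbon need not match or trail piperidin-1-yl. The widest span among these compounds is an at least 8.1-fold lower number from compound 2 to compound 4 (0.90 log units; beyond the scatter), but its size is only a bound, as compound 2 stands at a limit and not at a number: the limit of > 50000 nM in this assay, at which 1 of the 4 values shown sits.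

The substituent and its place on the phenyl ring change together in this exchange, so the compounds shown cannot tell whether the lower number in compound 4 follows the trifluoromethyl group or its place; 3-(trifluoromethyl)phenyl and 4-bromophenyl on the same nitrogen would separate the two. Also open, as far as these compounds go, is whether other groups in that place, such as 4-methoxyphenyl or 4-cyanophenyl, would give a lower number than compound 4 does.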